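The source may report more compounds than this note shows. Statements on the series, on what has been measured and on what is new or still open speak of the compounds shown alone.

- compound 1 `C=CCc1ccc(OCc2cn(-c3cccc(C#N)c3)nn2)c(O)c1` gives 30.9% as measured
- compound 2 `C=CCc1ccc(OCc2cn(-c3ccc(C(=O)c4ccccc4)cc3)nn2)c(O)c1` gives 40.5% as measured

In a functional assay on HL-60 cells (Homo sapiens) for inhibition, read by MTT assay, with a stated time of 72 h, tested at 50 uM (on this read-out higher numbers stand for more inhibition of growth at the one concentration tested and lower numbers for less inhibition of growth), compound 2 stands level with compound 1, as the gap between their values lies within the usual scatter. Compound 3 `C=CCc1ccc(OCc2cn(-c3ccc(Br)cc3)nn2)c(O)c1` has not been measured yet. It carries bromo in place of benzoyl on an aromatic carbon, para to a large group, and the counted change is bromo in place of benzoyl on an aromatic carbon here. Within the data shown here, no measured pair differs in just one place, so the data offer no step to compare with this change. No step beyond the scatter is expected, and the estimated move is a number 5.5 percentage points lower from compound 2 to compound 3 (within the scatter) in this case. For compound 3, the expected value is 35%, within an estimated range of 18% to 55% in this assay.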

Compound 3, percent growth inhibition at one concentration: 25.6%
Estimate against measurement, compound 3: 9.4 percentage points above; the range from low to high includes it.
By their numbers in this assay, from the lowest: compounds 3, 1 and 2 (each within the scatter of the next, the first and the last beyond it).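

In this assay, among these compounds, bromo in place of benzoyl on the aromatic carbon gives a number 14.9 percentage points lower from compound 2 to compound 3 (beyond the scatter), the first step here beyond the scatter, so what this position carries can change growth inhibition. By contrast, 4-bromophenyl in place of 3-cyanophenyl on the aromatic nitrogen gives a number 5.3 percentage points lower from compound 1 to compound 3 (within the scatter), a change too small to read as a real difference. Nothing measured here explains either step.

Going by these compounds, how an amine or a carboxylic acid on that same aromatic carbon would compare with bromo and benzoyl remains open.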